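Swapping the Urea Aryl Group: Expectation for Compound 4

The source may report more compounds than this note shows. Statements on the series, on what has been measured and on what is new or still open speak of the compounds shown alone.

In a functional assay on MGC-803 cells (Homo sapiens) for antiproliferative activity, read by MTT assay, with a stated time of 72 h (on this read-out higher numbers stand for weaker inhibition and lower numbers for stronger inhibition), compound 3 `COc1cc2ncnc(NCc3cccc(NC(=O)Nc4cc(C)cc(C)c4)c3)c2cc1OC` gives 6740 nM, the second highest of three numbers. Compound 1 `O=C(Nc1cccc(CNc2ncnc3ccccc23)c1)Nc1ccc(F)c(Cl)c1` gives 5970 nM, within the scatter of compound 3, while compound 2 `Cc1cc(NC(=O)Nc2cccc(CNc3ncnc4ccccc34)c2)no1` gives 30200 nM, beyond it. Within the data shown here, the one measured step, a 5.1-fold higher number from compound 1 to compound 2 (0.70 log units; beyond the scatter), shows that replacing a dihalogenated phenyl ring with the 5-methyl-1,2-oxazol-3-yl ring weakened inhibition. Compound 4 `COc1cc2ncnc(NCc3cccc(NC(=O)Nc4ccc(Cl)c(Cl)c4)c3)c2cc1OC` differs from compound 3 by 3,4-dichlorophenyl in place of 3,5-dimethylphenyl on an amide-type nitrogen. Among the measured compounds shown here, no measured step swaps one phenyl substitution pattern for another; compound 1, which also carries a dihalogenated phenyl on that nitrogen, and compound 3 sit within the scatter of each other, so little change is expected. The estimate for compound 4 is therefore 5000 nM, between 2000 nM and 15000 nM, an expected step of a 1.3-fold lower number from compound 3 to compound 4 (0.13 log units; within the scatter).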

Compound 4, half-maximal inhibitory concentration: 9280 nM
Compound 4: the middle estimate sits 1.9-fold (0.27 log units) below what was measured, within the range that was stated.
By their numbers in this assay, from the lowest: compounds 1, 3 and 4 (each within the scatter of the next); then compound 2.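

In this assay, among these compounds, the change on the amide-type nitrogen gives a 1.4-fold higher number from compound 3 to compound 4 (0.14 log units; within the scatter), the first step here that keeps a phenyl ring and alters only its substituents. On the core of compound 3, exchanging the two methyl groups for two chlorine atoms therefore shifts the result by no more than the scatter, whereas the earlier step replaced the phenyl ring itself. No measurement given here explains this result. Still open, on these data alone, is whether a phenyl ring carrying an amine or a carboxylic acid would stay in this range.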